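Benzylamine substituent exchange on the diamino core

A few compounds are considered here, and "the series" means these few. Any claim that something is new, unique, unknown or untested is made for them only; others in the source may bear on it.

Compound 3 `Nc1cc(N)c2nc(-c3ccccc3)c(NCc3ccc(Cl)c(Cl)c3)nc2c1` serves as the anchor here. In a functional assay on KM12 cells (Homo sapiens) for inhibition, read by sulforhodamine B assay, with a stated time of 48 h (a lower number here means a stronger inhibitor of growth, a higher number a weaker inhibitor of growth), compound 3 gives 21400 nM, the lowest of the two numbers in hand, although the nearest, compound 1 `Nc1cc(N)c2nc(-c3ccccc3)c(Oc3ccc(Cl)c(Cl)c3)nc2c1` with 39800 nM, sits within the scatter of it. Compound 2 `CCOC(=O)[C@H](CCC(=O)O)NC(=O)c1ccc(CNc2nc3cc(N)cc(N)c3nc2-c2ccccc2)cc1` yields only a limit in this assay, < 100000 nM. Compound 4 `COc1ccc(CNc2nc3cc(N)cc(N)c3nc2-c2ccccc2)cc1OC` differs from compound 3 by 3,4-dimethoxyphenyl in place of 3,4-dichlorophenyl on a saturated chain carbon bound to a nitrogen on an aromatic ring. For the measured compounds named here, no measured pair shows an exchange of this kind, so no direction can be read from the data; a step of small size, not beyond the scatter, is the expectation in this assay. Compound 4 is therefore estimated at 30000 nM in this assay, with a range of 8000 nM to 110000 nM. The step of a 1.4-fold higher number from compound 3 to compound 4 (0.15 log units; within the scatter) is an estimate only.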

Compound 4, concentration for total growth inhibition: 30900 nM
Compound 4: the middle estimate sits 1.0-fold (0.01 log units) below what was measured, within the range that was stated.
By their numbers in this assay, from the lowest: compounds 3, 4 and 1 (each within the scatter of the next).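

In this assay, for the compounds shown here, the exchange gives a 1.4-fold higher number from compound 3 to compound 4 (0.16 log units; within the scatter) and is the first step that can be read at this place, on a saturated chain carbon bound to a nitrogen on an aromatic ring. The numbers do not separate 3,4-dimethoxyphenyl from 3,4-dichlorophenyl here, although the entering group counts 2 hydrogen-bond acceptors and the leaving group 0. No measured property on hand bears on this step.

From the compounds shown here alone, whether an amine or a carboxylic acid in place of either aryl group, or a longer chain at this place, would give a step beyond the scatter remains open.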